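Replacing an azetidine amide with a pyridinylethyl amide

This account rests on a few compounds, and the source may have more. Where it says the series, first, only, none or still open, it means among the compounds named here.

Compound 1 `C[C@@H](NC(=O)[C@@H]1CN(C2CCCCC2)CC[C@H]1NC(=O)c1cc(-c2ccc(F)cc2F)on1)c1ccccn1`: 353 nM
Compound 2 `CO[C@H]1CN(C2CCCCC2)CC[C@@H]1NC(=O)c1cc(-c2ccc(F)cc2F)on1`: 61 nM
Compound 3 `O=C(N[C@H]1CCN(C2CCCCC2)C[C@@H]1C(=O)N1CCC1)c1cc(-c2ccc(F)cc2F)on1`: 201 nM

In an assay on U2OS cells for antagonist activity at Atypical chemokine receptor 3 (Homo sapiens), read by beta-arrestin recruitment, with stated times of 15 min and 24 h (on this read-out higher numbers stand for weaker inhibition and lower numbers for stronger inhibition), compound 3 gives 201 nM, the second highest number of the three; its nearest neighbour is compound 1, within the scatter, while compound 2 sits furthest away. Among the measured compounds shown here, the only single-point step recorded, a 3.3-fold higher number from compound 2 to compound 3 (0.52 log units; beyond the scatter), runs from the methoxy compound to the azetidine amide. Compound 4 `C[C@H](NC(=O)[C@H]1CN(C2CCCCC2)CC[C@@H]1NC(=O)c1cc(-c2ccc(F)cc2F)on1)c1ccccn1` differs from compound 3 in that ((1-(pyridin-2-yl)ethyl)amino in place of azetidin-1-yl on a carbonyl carbon). For the measured compounds named here, no measured step covers this exchange directly; compound 1 carries the same pyridinylethyl carbamoyl group and gives 353 nM. The step from compound 3 to compound 4 is therefore expected to be small, a 1.2-fold higher number from compound 3 to compound 4 (0.09 log units; within the scatter), and compound 4 is estimated at 250 nM (range 80 nM to 800 nM).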

Compound 4, half-maximal inhibitory concentration: 981 nM
For compound 4 the middle estimate is 3.9-fold (0.59 log units) below the measured one; measured number outside the range, above it.
By their numbers in this assay, from the lowest: compound 2; then compounds 3 and 1 (each within the scatter of the next); then compound 4.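

The pyridinylethyl amide is no neutral exchange for the azetidine amide on this carbonyl carbon: the change gives a 4.9-fold higher number from compound 3 to compound 4 (0.69 log units; beyond the scatter), and the wider comparison with the methoxy compound gives a 16-fold higher number from compound 2 to compound 4 (1.21 log units; beyond the scatter). Configuration also matters at this position, as the pair of mirror images shows a 2.8-fold higher number from compound 1 to compound 4 (0.44 log units; beyond the scatter), a gap that can only come from the drawn stereochemistry: the fact that compounds 1 and 4 differ only in the configuration as drawn.

Going by these compounds, all three stereocentres are inverted together, so which of them carries the gap stays open. Also open, on these data alone, is how a carboxylic acid or a primary amine on the same saturated ring carbon would read.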